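A few compounds are considered here, and "the series" means these few. Any claim that something is new, unique, unknown or untested is made for them only; others in the source may bear on it.

Measured compounds in this series:

compound 1 `CCC(=O)N(C)c1ccc2[nH]c(-c3n[nH]c4ccccc34)cc2n1`: 33500 nM
compound 2 `COc1ccc(C(=O)N(C)c2ccc3[nH]c(-c4n[nH]c5ccccc45)cc3n2)cc1`: 23700 nM
compound 3 `COc1cccc(C(=O)N(C)c2ccc3[nH]c(-c4n[nH]c5ccccc45)cc3n2)c1`: 22000 nM

All three were read in a functional assay on SMMC-7721 cells (Homo sapiens) for antiproliferative activity, read by MTT assay, with a stated time of 72 h; a higher number here means a weaker inhibitor, a lower number a stronger inhibitor. Compound 3 stands lowest of the three numbers, but the separation is slight: a 1.5-fold lower number from compound 1 to compound 3 (0.18 log units; within the scatter), and a 1.1-fold lower number from compound 2 to compound 3 (0.03 log units; within the scatter), both within the scatter, so no order among the three can be claimed.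

The unmeasured compound 4 `CN(C(=O)c1ccc([N+](=O)[O-])cc1)c1ccc2[nH]c(-c3n[nH]c4ccccc34)cc2n1` differs from compound 3 only at the carbonyl substituent: 4-nitrophenyl in place of 3-methoxyphenyl on a carbonyl carbon. Among the compounds with values here, the steps that bear on this position are the three already made, all exchanging one group on the same carbonyl carbon: a 1.4-fold lower number from compound 1 to compound 2 (0.15 log units; within the scatter), a 1.5-fold lower number from compound 1 to compound 3 (0.18 log units; within the scatter), a 1.1-fold lower number from compound 2 to compound 3 (0.03 log units; within the scatter). None of them moved this assay beyond the scatter, whether the group was a short chain or an aryl ring carrying one acceptor. On that basis compound 4 is expected to sit close to compound 3, with a step of no change at the digits printed from compound 3 to compound 4 (within the scatter) that is expected to stay within the scatter. The estimate for compound 4 in this assay is 22000 nM, with an expected range from 10000 nM to 50000 nM.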

Compound 4, half-maximal inhibitory concentration: 18400 nM
Beside the measured number, compound 4's estimate is 1.2-fold (0.08 log units) above it; the range from low to high includes it.
By their numbers in this assay, from the lowest: compounds 4, 3, 2 and 1 (each within the scatter of the next).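

Placing a nitro-bearing ring on the carbonyl carbon extends the set beyond an ethyl group and methoxy-bearing rings, yet this assay still separates none of them: a 1.2-fold lower number from compound 3 to compound 4 (0.08 log units; within the scatter). The same holds for the direct exchange of nitro in place of methoxy on an aromatic carbon, a 1.3-fold lower number from compound 2 to compound 4 (0.11 log units; within the scatter), and for the exchange of ethyl for 4-nitrophenyl, a 1.8-fold lower number from compound 1 to compound 4 (0.26 log units; within the scatter). No measurement is available to explain this flat response.

Going by these compounds, whether an amine, a carboxylic acid or a longer chain on this carbonyl carbon would produce a step beyond the scatter remains open. The compounds shown vary only this substituent, so the effect of changes elsewhere on the shared core also remains unknown.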